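Trifluoroacetamide in Place of the Piperidinyl Ester

The source may hold more compounds than are shown below. What is called first, only, known or untested is meant among the compounds shown, and "the series" means these compounds.

Three compounds of the shared core have been measured in an ADME assay on HEK293-A cells (Homo sapiens) for cytotoxicity, read by MTT assay, with a stated time of 48 h; on this read-out lower numbers stand for stronger inhibition and higher numbers for weaker inhibition:

compound 1, `O=C1O[C@@H](CO)CN1c1ccc(-n2cc(-c3ccccn3)cn2)c(F)c1`, gives only a limit, > 400 ug/mL
compound 2, `COC(=O)CC1CCN(C[C@H]2CN(c3ccc(-n4cc(-c5ccccn5)cn4)c(F)c3)C(=O)O2)CC1`, gives 224 ug/mL
compound 3, `CCNC(=O)NC[C@H]1CN(c2ccc(-n3cc(-c4ccccn4)cn3)c(F)c2)C(=O)O1`, gives 29 ug/mL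

Among the two numbers, compound 2 stands highest; compound 3 sits a 7.7-fold lower number from compound 2 to compound 3 (0.89 log units; beyond the scatter) away from it. Compound 1 is known only as a limit of this assay, (the limit of > 400 ug/mL in this assay, at which 1 of the 3 values shown sits).

Compound 4, `O=C1O[C@@H](CNC(=O)C(F)(F)F)CN1c1ccc(-n2cc(-c3ccccn3)cn2)c(F)c1`, is not yet measured. Relative to compound 2 the change is ((trifluoromethyl)carbonyl)amino in place of 4-((methoxycarbonyl)methyl)piperidin-1-yl on a saturated chain carbon bound to a saturated ring carbon.

For the measured compounds named here, two measured steps bear on this change. The step of a 7.7-fold lower number from compound 2 to compound 3 (0.89 log units; beyond the scatter) also removes the 4-((methoxycarbonyl)methyl)piperidin-1-yl group at this place and brings in a small group carrying one hydrogen-bond donor, as the entering ((trifluoromethyl)carbonyl)amino group does. The step of an at least 1.7-fold lower number from compound 1 to compound 2 (0.25 log units; that floor lies within the scatter) and the step of an at least 13-fold lower number from compound 1 to compound 3 (1.13 log units; beyond the scatter) show that a small hydroxy group at this place leaves the number at a limit, and that replacing it with a donor-bearing group lowers the number beyond the scatter.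

Compound 4 is therefore expected to give a lower number than compound 2, by a step of a 2.8-fold lower number from compound 2 to compound 4 (0.45 log units; beyond the scatter), while staying short of the limit. The estimate for compound 4 in this assay is 80 ug/mL, within 25 ug/mL to 300 ug/mL.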

Compound 4, half-maximal inhibitory concentration: > 400 ug/mL
Compound 4 ended at the assay's limit; the forecaster's own chance of this, stated with the estimate: 15%; middle value at least 5.0-fold (0.69 log units) away from the limit.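

In this assay compound 4 gives only a limit, the same standing as compound 1: the limit of > 400 ug/mL in this assay, at which 2 of the 4 values shown sit. Trifluoromethyl in place of ethylamino on a carbonyl carbon gives an at least 13-fold higher number from compound 3 to compound 4 (1.13 log units; beyond the scatter), so the earlier link between a donor-bearing group at this place and a lower number rests on compound 3 alone, and compound 4 goes against it. The change from the piperidinyl ester gives an at least 1.7-fold higher number from compound 2 to compound 4 (0.25 log units; that floor lies within the scatter), a floor that does not set the pair apart beyond the scatter, and the step that joins the two limits cannot be read.

The compounds shown leave open whether the higher number depends on the trifluoromethyl group itself or on losing the ethylamino group from the carbonyl carbon, a question that an acetylamino group or a free amine on the saturated chain carbon could help to separate. As far as these compounds go, they also leave open the real numbers that lie behind the limits, so the ranking of the hydroxy and ((trifluoromethyl)carbonyl)amino groups at this place remains unknown.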